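This account rests on a few compounds, and the source may have more. Where it says the series, first, only, none or still open, it means among the compounds named here.

Measured in a functional assay on KB cells (Homo sapiens) for cytotoxicity; a higher number here means that more compound is needed for the effect, a lower number that less compound is needed:
- compound 1 `COC1=C(C)C(=O)/C(=C(O)/C=C/c2ccccc2C)C(=O)C1(C)C`: 4.1 ug/mL
- compound 2 `COC1=C(C)C(=O)/C(=C(O)/C=C/c2c(C)cc(C)cc2C)C(=O)C1(C)C`: > 20 ug/mL, a limit of the assay and not a number
- compound 3 `COC1=C(C)C(=O)/C(=C(O)/C=C/c2cccc3ccccc23)C(=O)C1(C)C`: 2.8 ug/mL

Compound 1 at 4.1 ug/mL and compound 3 at 2.8 ug/mL lie within the scatter of each other, so neither can be ranked over the other. Compound 2 is the only one of the series without a numerical value, its reading being a limit.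

Compound 4 `COC1=C(C)C(=O)/C(=C(O)/C=C/c2nccs2)C(=O)C1(C)C` carries 1,3-thiazol-2-yl in place of 2-methylphenyl on a double-bonded chain carbon bound to a double-bonded chain carbon. Among the compounds with values here, no measured pair isolates a change of this kind, so the expectation rests on the three readings alone. Compound 3 at 2.8 ug/mL shows that one other replacement of the group in compound 1 kept a measured number. The limit of compound 2 warns that another replacement did not. The step of a 1.7-fold higher number from compound 1 to compound 4 (0.23 log units; within the scatter) is expected to be small, towards a higher number and not clearly beyond the scatter. Compound 4 is estimated at 7 ug/mL, with an expected range from 2.5 ug/mL to 20 ug/mL.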

Compound 4, concentration for half-maximal effect: 4.3 ug/mL
Beside the measured number, compound 4's estimate is 1.6-fold (0.21 log units) above it, within the range that was stated.
By their numbers in this assay, from the lowest: compounds 3, 1 and 4 (each within the scatter of the next). At a limit, above all of these: compound 2.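

In this assay the replacement of 2-methylphenyl by 1,3-thiazol-2-yl on a double-bonded chain carbon bound to a double-bonded chain carbon gives a 1.0-fold higher number from compound 1 to compound 4 (0.02 log units; within the scatter) and so leaves compound 1 and compound 4 indistinguishable. Within the data shown here, this single-place pair shows what the earlier compounds could not: at this position, a five-membered aromatic ring with 2 hetero atoms and 2 hydrogen-bond acceptors can stand in place of a six-membered aromatic ring of carbon only and still give a reading within the scatter of compound 1. Nothing measured here accounts for this outcome.

The compounds shown leave open how a plain phenyl or a pyridin-2-yl ring would read at this position. They also leave open whether an amine, a carboxylic acid or a longer chain there would keep a measurable reading.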